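This account rests on a few compounds, and the source may have more. Where it says the series, first, only, none or still open, it means among the compounds named here.

Of the compounds shown here, three built on a shared core have been tested in a functional assay on Malme-3M cells (Homo sapiens) for cytotoxicity, read by MTT assay, with a stated time of 6 days; a lower number here means that less compound is needed, a higher number that more compound is needed for the effect. Compound 1 `COC(=O)c1c(-c2ccc(O)cc2)oc2ccccc2c1=O` gives > 25 ug/mL in this assay, and this is a limit of the measurement rather than a number. Compound 2 `COC(=O)c1c(-c2ccc(O)cc2)oc2ccc(OC)cc2c1=O` gives > 25 ug/mL in this assay, again only a limit. Compound 3 `COc1cc(-c2oc3ccccc3c(=O)c2C(=O)O)cc(OC)c1OC` gives > 25 ug/mL in this assay, also a limit. From compound 2 to compound 1 the change is hydrogen in place of methoxy on an aromatic carbon, and the step that the two limits leave unreadable from compound 2 to compound 1 cannot be read because both ends are limits. How the core of compound 3 differs from the core of compound 2 is not broken down here. Compound 4 `COc1cc(OC)cc(-c2oc3ccccc3c(=O)c2C(=O)O)c1` has not yet been measured; it differs from compound 3 by hydrogen in place of methoxy on an aromatic carbon. This is the same kind of change as from compound 2 to compound 1, but the surroundings differ: in compound 3 the place is ortho to two methoxy groups and para to a large group, and not part of a fused system of two rings. Within the data shown here, because every value so far sits at the limit of > 25 ug/mL in this assay, at which 3 of the 3 values shown sit, the step that the limit leaves unreadable from compound 3 to compound 4 is expected to be small. Compound 4 is therefore estimated at 30 ug/mL, most likely again reported only as a limit, somewhere between 12 ug/mL and 80 ug/mL.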

Compound 4, concentration for half-maximal effect: > 25 ug/mL
Compound 4: no number, only a limit; the forecaster's own chance of this, stated with the estimate: 85%; the middle value lies beyond the limit too.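

No new step can be read between compound 3 and compound 4 in this assay because neither compound gives a number, only a limit: the limit of > 25 ug/mL in this assay, at which 4 of the 4 values shown sit. The compounds shown leave open whether swapping methoxy for hydrogen changes cytotoxicity at all, and what actual number any of the four compounds would give.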